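Swapping the Side Chain Before the Tail Flick Result

The compounds below may be only part of what the source reports. "The series", "measured", "known", "first", "only" and "open" are said of these compounds alone.

Of the compounds shown here, two have been measured. Compound 1, `NC(=O)C[C@H](NC(=O)CN(c1nc(Cl)nc2[nH]cnc12)C1CC1)C(=O)O`, and compound 2, `CC(C)C[C@H](NC(=O)CN(c1nc(Cl)nc2[nH]cnc12)C1CC1)C(=O)O`, share one core and differ in a single group. In a functional assay on the whole organism (Tail, strain ICR) with Mus musculus as the target, in the tail flick test, with a stated time of 30 min, at a dose of 25 umol/kg by the oral route (a higher number here means a stronger effect of the compound at the dose given, a lower number a weaker effect), compound 1 gives 29.7%, and compound 2 gives 23.4%. Going by the values given here, the step between them, a number 6.3 percentage points lower from compound 1 to compound 2 (within the scatter), is small enough that the two numbers cannot be told apart, so compound 2 stands within the usual scatter of the only other compound.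

Compound 3, `NCCCC[C@H](NC(=O)CN(c1nc(Cl)nc2[nH]cnc12)C1CC1)C(=O)O`, has not yet been measured. It differs from compound 2 by 3-aminopropyl in place of isopropyl on a saturated chain carbon, two bonds along the chain from an amide-type nitrogen and a carbonyl carbon. Among the compounds with values here, the only measured step that touches this position is a number 6.3 percentage points lower from compound 1 to compound 2 (within the scatter), and it stayed within the scatter; on that basis a step of about a number 2.6 percentage points higher from compound 2 to compound 3 (within the scatter) is expected, with no direction beyond the scatter. Compound 3 is therefore estimated at 26%, with a range from 12% to 40%.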

Compound 3, a percentage reported as activity, at one dose (the size of the read-out at that dose, not a potency): 31.2%
Beside the measured number, compound 3's estimate is 5.2 percentage points below it; measured number inside the range.
By their numbers in this assay, from the lowest: compounds 2, 1 and 3 (each within the scatter of the next).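

Placing 3-aminopropyl on the saturated chain carbon gives, in this assay, a number 7.8 percentage points higher from compound 2 to compound 3 (within the scatter) and a number 1.5 percentage points higher from compound 1 to compound 3 (within the scatter) as well. This position has now carried isopropyl, which has no nitrogen, and two groups that contain one, carbamoyl and 3-aminopropyl, yet the three compounds cannot be told apart in this read-out at the single dose given. No supporting measurement is available to explain why these changes leave the numbers so close.

On these data alone, it remains open whether a carboxylic acid or a phenyl ring at this position would stay within the same scatter, or whether a longer chain ending in an amine would do so. With only one dose and one time point shown, these compounds also leave open whether any differences would appear under other conditions.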